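The compounds below may be only part of what the source reports. "The series", "measured", "known", "first", "only" and "open" are said of these compounds alone.

Compound 3 `CCCC(C)n1c(CC)nc2c(-c3ccc(Cl)cc3C(C)=O)ccnc21` stands at the highest number of the three measured in an assay for binding affinity to Corticotropin releasing factor receptor (Rattus norvegicus) (a higher number here means a weaker inhibitor, a lower number a stronger inhibitor), where compound 3 gives 95.6 nM. Compound 1 `CCc1nc2c(-c3ccc(Cl)cc3Cl)ccnc2n1C(CCOC)C1CC1` gives 1.5 nM and compound 2 `CCc1nc2c(-c3ccc(C(F)(F)F)cc3Cl)ccnc2n1C(CC)CCOC` gives 0.7 nM; both gaps to compound 3 lie beyond the scatter. Compound 4 `CCCC(C)n1c(CC)nc2c(-c3ccc(Cl)cc3Cl)ccnc21` is compound 3 with one change: chloro in place of acetyl on an aromatic carbon. Compound 4 thereby carries the same substitution on that aromatic ring as compound 1, differing from it only at the core. Within the data shown here, no measured pair isolates this change, so the expectation rests on what the values show. Compound 4 is expected to give a much lower number, a step of a 32-fold lower number from compound 3 to compound 4 (1.50 log units; beyond the scatter), because compound 1 gives 1.5 nM with the same two chloro groups. The estimate for compound 4 in this assay is 3 nM, within 1 nM to 15 nM.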

Compound 4, inhibition constant: 0.5 nM
For compound 4 the middle estimate is 6.0-fold (0.78 log units) above the measured one; measured number below the stated range.
By their numbers in this assay, from the lowest: compounds 4 and 2 (each within the scatter of the next); then compound 1; then compound 3.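

Chloro in place of acetyl on an aromatic carbon, ortho to a large group, is a large step in this assay (a 190-fold lower number from compound 3 to compound 4 (2.28 log units; beyond the scatter)), showing that this position separates these two groups sharply. By contrast, 1-methylbutyl in place of 1-cyclopropyl-3-methoxypropyl on an aromatic nitrogen is only a modest step (a 3.0-fold lower number from compound 1 to compound 4 (0.48 log units; beyond the scatter)). Nothing given here accounts for either step.

Going by these compounds, whether a methoxy group or a nitrile at this position would fall nearer chloro or acetyl stays open. So does whether the acetyl penalty persists with 1-cyclopropyl-3-methoxypropyl on the nitrogen.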